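This account rests on a few compounds, and the source may have more. Where it says the series, first, only, none or still open, it means among the compounds named here.

Compound 1 `ClCc1ccc(Cn2cnc3c(Cl)ncnc32)cc1` is the reference point of this small set. In a functional assay on DU-145 cells (Homo sapiens) for cytotoxicity, read by sulforhodamine B assay, with a stated time of 48 h (on this read-out higher numbers stand for weaker inhibition of growth and lower numbers for stronger inhibition of growth), compound 1 gives 1310 nM. Compound 2 `ClCc1ccccc1Cn1cnc2ncnc(Cl)c21` is made of the same atoms as compound 1, joined differently; the difference between the two cores is not broken down here. In this assay, going by the values given here, compound 2 gives 2950 nM, the second highest of the three numbers so far, and its gap to compound 1 lies beyond the scatter. Compound 3 `ClCc1ccc(Cn2cnc3c(Cl)nc(Cl)nc32)cc1` differs from compound 1 by chloro in place of hydrogen on an aromatic carbon. In this assay compound 3 gives 5620 nM, so the step of a 4.3-fold higher number from compound 1 to compound 3 (0.63 log units; beyond the scatter) is a clear loss, while compound 3 and compound 2 lie within the scatter of one another.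

Compound 4 `ClCc1ccccc1Cn1cnc2nc(Cl)nc(Cl)c21` has not yet been measured. Among the compounds with values here, it differs from compound 2 by chloro in place of hydrogen on an aromatic carbon, the same change, in the same place, as the one that separates compound 1 from compound 3. The step expected here is a 3.7-fold higher number from compound 2 to compound 4 (0.57 log units; beyond the scatter). Within the data shown here, that expectation rests on compound 1 and compound 3, because a 4.3-fold higher number from compound 1 to compound 3 (0.63 log units; beyond the scatter) is the only precedent for this change and it moved the number modestly upward. With a single precedent the range is kept wide. Compound 4 is therefore expected to give 11000 nM in this assay, most likely falling between 4500 nM and 28000 nM.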

Compound 4, concentration for 50% growth inhibition: 5490 nM
Compound 4: the middle estimate sits 2.0-fold (0.30 log units) above what was measured; low and high end bracket the measured number.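

In this assay, chloro in place of hydrogen on an aromatic carbon, at the place between two ring nitrogen atoms, gives a 1.9-fold higher number from compound 2 to compound 4 (0.27 log units; within the scatter), so on this core the change stays within the scatter, whereas on the core of compound 1 it lay beyond it. Set side by side, the two steps cannot be told apart: the same change on two cores in this assay, a 4.3-fold higher number (0.63 log units; beyond the scatter) from compound 1 to compound 3 and a 1.9-fold higher number (0.27 log units; within the scatter) from compound 2 to compound 4, 2.3-fold (0.36 log units) apart, within the scatter of two such steps. Going by these compounds alone, this shows that a single step size shared by both cores fits the data and gives no ground for saying that the core alters what the chloro does, but it does not show that the change carries over reliably, as only two pairs stand behind it and only one of the two steps can be read on its own beyond the scatter.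

What the compounds shown leave open is how an amine or a methoxy group at this same place would read in this assay, as hydrogen and chloro are the only groups seen there. Equally open, on these data alone, is whether the step would hold on a third core, and whether the chloromethyl group, present in all four compounds, could give way to a hydroxymethyl group without moving the number.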